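Inverting both drawn stereocentres of compound 3

The source may report more compounds than this note shows. Statements on the series, on what has been measured and on what is new or still open speak of the compounds shown alone.

Of the compounds shown here, three have been measured so far in an ADME assay on L6 cells (Rattus norvegicus) for cytotoxicity, read by resazurin assay, with a stated time of 70 h; on this read-out lower numbers stand for an effect already at smaller amounts and higher numbers for an effect only at larger amounts of compound. Compound 1 `CC(=O)Nc1cnc2[nH]c(=O)n([C@H]3CC[C@@H](C(C)C)CC3)c(=O)c2c1` gives 16000 nM. Compound 2 `CC(C)(C)[C@H]1CC[C@@H](n2c(=O)[nH]c3ncc(N)cc3c2=O)CC1` gives 44000 nM. Compound 3 `CC(C)[C@H]1CC[C@H](n2c(=O)[nH]c3ncc(N)cc3c2=O)CC1` gives 46000 nM.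

Compound 3 stands level with compound 2, within the scatter, and its number lies above that of compound 1, beyond the scatter.

The next compound is compound 4 `CC(C)[C@H]1CC[C@@H](n2c(=O)[nH]c3ncc(N)cc3c2=O)CC1`. The change is the two compounds have the same atoms and bonds and differ only in configuration as drawn: 2 of 2 stereo elements differ (all stereocentres are inverted: mirror images); a stereocentre at a saturated ring carbon is drawn r in compound 3 and s in compound 4; a stereocentre at a saturated ring carbon is drawn r in compound 3 and s in compound 4. No group leaves or enters, and all stereocentres are inverted.

Within the data shown here, no measured pair shows a change of this kind, so the data give no direct size for it. The best anchor is compound 3 at 46000 nM. The expectation in this assay is therefore no step beyond the scatter, and no direction is favoured. The estimated 1.2-fold lower number from compound 3 to compound 4 (0.06 log units; within the scatter) is expected to remain small. For compound 4 the expected value is 40000 nM, with an estimated range of 18000 nM to 90000 nM.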

Compound 4, half-maximal effective concentration in the L6 assay: 46000 nM
Compound 4: middle estimate off by 1.2-fold (0.06 log units), on the low side; low and high end bracket the measured number.
By their numbers in the L6 assay, from the lowest: compound 1; then compounds 2, 3 and 4 (each within the scatter of the next).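

Among these compounds, in the L6 assay, inverting both drawn stereocentres is read for the first time, and the step shows no change at the digits printed from compound 3 to compound 4 (within the scatter). In a physicochemical assay for solubility, read by nephelometry, measured as kinetic solubility (a higher number here means a more soluble compound, a lower number a less soluble compound), compound 3 gives 25000 nM and compound 4 gives 17000 nM. In the physicochemical assay the same change gives a 1.5-fold lower number from compound 3 to compound 4 (0.17 log units; within the scatter), so neither read-out separates the pair beyond the scatter. In the L6 assay, compound 4 also anchors two single-place comparisons: hydrogen in place of methyl on a saturated chain carbon bound to two saturated chain carbons and a saturated ring carbon gives a 1.0-fold higher number from compound 2 to compound 4 (0.02 log units; within the scatter), while hydrogen in place of acetyl on a nitrogen on an aromatic ring gives a 2.9-fold higher number from compound 1 to compound 4 (0.46 log units; beyond the scatter). Reading the first comparison as a test of configuration alone rests on one point: the fact that compounds 3 and 4 differ only in the configuration as drawn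

Open, as far as these compounds go, is what a longer acyl chain or a sulfonamide on that nitrogen would do in the L6 assay. One pair also cannot show whether configuration stays this silent with acetyl on that nitrogen.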